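The source may report more compounds than this note shows. Statements on the series, on what has been measured and on what is new or still open speak of the compounds shown alone.

Compound 3 `CCCCN(C1=NCCN1)c1c(Br)cccc1Br` stands lowest of the three measured compounds in a physicochemical assay for lipophilicity (a higher number here means a more lipophilic compound, a lower number a more polar compound), at -2.5. Compound 1 `Brc1cccc(Br)c1N(CC1CC1)C1=NCCN1` gives -1.12, and compound 2 `Brc1ccc(Br)c(N(CC2CC2)C2=NCCN2)c1` gives -0.52. The next compound, compound 4 `CC(C)CN(C1=NCCN1)c1c(Br)cccc1Br`, has the same atoms as compound 3, joined differently: isopropyl in place of propyl on a saturated chain carbon bound to a nitrogen on an aromatic ring. The change is isopropyl in place of propyl on a saturated chain carbon bound to a nitrogen on an aromatic ring, which, cut one bond further out, reads butyl to isobutyl.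

For the measured compounds named here, only one measured step bears on this place: a number 1.38 log units lower from compound 1 to compound 3 (beyond the scatter), a large step with propyl in place of cyclopropyl. Going by the values given here, compound 2 offers no measured step to compound 3. Among the compounds with values here, no measurement yet tests propyl against isopropyl, so the guide is indirect. A rise of moderate size is expected, recovering only part of that large step, though the uncertainty is wide. The estimated step is a number 0.60 log units higher from compound 3 to compound 4 (beyond the scatter). In this assay, compound 4 is expected at -1.9, within an estimated range of -2.7 to -1.2.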

Compound 4, distribution coefficient: -0.64
Compound 4: middle estimate off by 1.26 log units, on the low side; measured number above the stated range.
By their numbers in this assay, from the lowest: compound 3; then compound 1; then compounds 4 and 2 (each within the scatter of the next).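

In this assay, moving the same atoms at this place, on a saturated chain carbon bound to a nitrogen on an aromatic ring, gives a number 1.86 log units higher from compound 3 to compound 4 (beyond the scatter), although propyl and isopropyl have the same count of heavy atoms and neither has a ring. Isopropyl in place of cyclopropyl gives a number 0.48 log units higher from compound 1 to compound 4 (beyond the scatter), so among these three groups at this place, propyl gives the lowest number and isopropyl the highest. For the compounds shown here, nothing available explains why this rearrangement of the same atoms shifts the number so far.

On these data alone, it remains open how a longer chain such as pentyl, or a chain carrying an amine, would compare at this place. As far as these compounds go, it is also open whether propyl and isopropyl would differ as widely on the core of compound 2.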